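Adding a chloro group to compound 2

This account rests on a few compounds, and the source may have more. Where it says the series, first, only, none or still open, it means among the compounds named here.

Values in a functional assay on MDA-MB-435 cells (Homo sapiens) for inhibition, read by sulforhodamine B assay, with a stated time of 48 h; on this read-out higher numbers stand for weaker inhibition of growth and lower numbers for stronger inhibition of growth:
- compound 1 `N#Cc1c(-c2nnc(O)c3nn(-c4ccc(Cl)cc4)cc23)nn(-c2ccccc2)c1-c1ccccc1`: > 100000 nM
- compound 2 `N#Cc1c(-c2nnc(-c3nn(-c4ccccc4)c(-c4ccccc4)c3C#N)c3nn(-c4ccccc4)cc23)nn(-c2ccccc2)c1-c1ccccc1`: > 100000 nM

Compound 2 gives > 100000 nM in this assay, and this is a limit of the assay, not a number. The same holds for both measured compounds: the limit of > 100000 nM in this assay, at which 2 of the 2 values shown sit. Among the measured compounds shown here, no single-place step between measured compounds is available, so the data give no size for any structural change.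

Compound 3 `N#Cc1c(-c2nnc(-c3nn(-c4ccccc4)c(-c4ccccc4)c3C#N)c3nn(-c4ccc(Cl)cc4)cc23)nn(-c2ccccc2)c1-c1ccccc1` differs from compound 2 in one place: chloro in place of hydrogen on an aromatic carbon. This is chloro in place of hydrogen on an aromatic carbon, phenyl to 4-chlorophenyl.

No step beyond the usual scatter is expected, and no direction can be assigned. The estimated step is a number no higher from compound 2 to compound 3 (the limit leaves the size open). A further limit is the likeliest outcome. For compound 3 the expected value is 100000 nM, with an estimated range of 30000 nM to 200000 nM.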

Compound 3, concentration for 50% growth inhibition: 9200 nM
The estimate for compound 3 lay 11-fold (1.04 log units) above the measured number; measured number outside the range, below it.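

Phenyl to 4-chlorophenyl on this ring gives, in this assay, an at least 10-fold lower number from compound 2 to compound 3 (1.03 log units; beyond the scatter), so a single chlorine atom at this aromatic carbon is enough to bring a compound of this series off the limit and give a first real number. From the compounds shown here alone, the true size of the step stays unknown, since compound 2 sits at a limit of the assay: the limit of > 100000 nM in this assay, at which 2 of the 3 values shown sit. The 4-chlorophenyl group does not carry this result on its own terms, as compound 1 also bears it and gives > 100000 nM, which is likewise a limit.

Going by these compounds, whether fluoro, bromo, methyl or methoxy on the same carbon gives a comparable step remains open. So does the effect of chloro on the other phenyl rings of compound 3.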